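Moving a trifluoromethyl group on a hydrazone phenyl ring

A few compounds are considered here, and "the series" means these few. Any claim that something is new, unique, unknown or untested is made for them only; others in the source may bear on it.

Three compounds share one core, a thiazole-based scaffold drawn in full below; compound 1 is `CN(C(=O)NC(=O)c1c(F)cccc1F)c1nc(C(F)(F)F)c(C(=O)N/N=C/c2cccc(C(F)(F)F)c2)s1` and compound 2 is `CN(C(=O)NC(=O)c1ccc(C(F)(F)F)cc1)c1nc(C(F)(F)F)c(C(=O)N/N=C/c2cccc(C(F)(F)F)c2)s1`. In an ADME assay on L02 cells (Homo sapiens) for inhibition, read by MTT assay, with a stated time of 72 h (a higher number here means a weaker inhibitor, a lower number a stronger inhibitor), compound 1 gives "not determined" (no result reported), so no number exists for it. In this assay compound 2 gives 18 ug/mL, and this is the only number shown for any compound, so there is no second value to set it against and no step between measured compounds to learn from. Compound 3 is `CN(C(=O)NC(=O)c1ccc(C(F)(F)F)cc1)c1nc(C(F)(F)F)c(C(=O)N/N=C/c2ccccc2C(F)(F)F)s1`; it has the same atoms as compound 2, joined differently: 2-(trifluoromethyl)phenyl in place of 3-(trifluoromethyl)phenyl on a carbon with a double bond to nitrogen. For the measured compounds named here, with no measured step of this kind available, the expected effect is none beyond the usual scatter, in no particular direction, so the step from compound 2 to compound 3 in this assay is estimated at no change at the digits printed from compound 2 to compound 3 (within the scatter). For compound 3 in this assay the expected value is therefore 18 ug/mL, within a range from 8 ug/mL to 40 ug/mL.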

Compound 3, half-maximal inhibitory concentration: 12.4 ug/mL
Compound 3: middle estimate off by 1.5-fold (0.16 log units), on the high side; low and high end bracket the measured number.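

With 2-(trifluoromethyl)phenyl in place of 3-(trifluoromethyl)phenyl on a carbon with a double bond to nitrogen, this assay gives a 1.5-fold lower number from compound 2 to compound 3 (0.16 log units; within the scatter) as the step, so these two arrangements of the same atoms cannot be told apart in this read-out. For the compounds shown here, this is the first measured step at this position, since a single number on its own could show nothing about how the position responds to such a swap. No supporting measurement is available to account for the result.

Both compounds compared here carry trifluoromethyl on this phenyl ring, so the result says nothing about other groups there, such as a methoxy group, an amine or a carboxylic acid. Whether a larger step can arise at this position remains an open question.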